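Swapping a butyl end for a ring-bearing group

A few compounds are considered here, and "the series" means these few. Any claim that something is new, unique, unknown or untested is made for them only; others in the source may bear on it.

- compound 1 `Clc1ccccc1CCCN1CCC(COC(c2ccccc2)c2ccccc2)CC1` gives 800 nM
- compound 2 `CCCCCN1CCC(COC(c2ccccc2)c2ccccc2)CC1` gives 10800 nM

In a functional assay on cells (T-cell line, Homo sapiens) for inhibition (a higher number here means a weaker inhibitor, a lower number a stronger inhibitor), compound 2 (10800 nM) has the higher of the two numbers, which makes it the weaker inhibitor of the pair. Compound 3 `c1ccc(C(OCC2CCN(CC3CCc4ccccc4C3)CC2)c2ccccc2)cc1` keeps the shared core but carries 1,2,3,4-tetrahydronaphthalen-2-yl in place of butyl on a saturated chain carbon bound to an amine nitrogen in a ring. For the measured compounds named here, only one measured step bears on this change. It is a 14-fold higher number from compound 1 to compound 2 (1.13 log units; beyond the scatter) and it is large. In that step, ethyl replaces 2-chlorophenyl, so a chain without a ring gave the weaker compound. Compound 3 regains an aromatic ring, but this is a single pair with a different chain, so the step can only be a rough guide. The step expected in this assay is a 6.0-fold lower number from compound 2 to compound 3 (0.78 log units; beyond the scatter) and so a lower number, though probably short of the full distance to compound 1. Compound 3 is estimated at 1800 nM with 500 nM to 6000 nM as the expected range.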

Compound 3, half-maximal inhibitory concentration: 5600 nM
Compound 3: the middle estimate sits 3.1-fold (0.49 log units) below what was measured; the range from low to high includes it.
By their numbers in this assay, from the lowest: compound 1; then compounds 3 and 2 (each within the scatter of the next).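

In this assay, the step of a 1.9-fold lower number from compound 2 to compound 3 (0.29 log units; within the scatter) stays within the usual scatter, so at this position 1,2,3,4-tetrahydronaphthalen-2-yl cannot be told apart from butyl, even though it brings one six-membered aromatic ring and one six-membered non-aromatic ring. The step of a 7.0-fold higher number from compound 1 to compound 3 (0.85 log units; beyond the scatter) lies beyond the scatter, so compound 3 goes against any simple rule that an aromatic ring in this group is enough to match the 2-(2-chlorophenyl)ethyl group of compound 1. Nothing available explains the gap between these two ring-bearing groups.

These three compounds leave open whether the chlorine of compound 1 matters, which a plain 2-phenylethyl group at the same place would help to show. They also leave open whether the ring must sit at the end of an open chain, as it does in compound 1, or whether a 3-phenylpropyl group, with its longer chain, would give a lower number still in this assay.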